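Methyl on the Shared Core, Carried to a Second Series

The compounds below may be only part of what the source reports. "The series", "measured", "known", "first", "only" and "open" are said of these compounds alone.

Compound 1 `COCOc1ccccc1-c1cc2ccccc2c(=O)n1C` and compound 2 `COCOc1ccccc1-c1cc2cc(C)ccc2c(=O)n1C` share one core, compound 3 `COc1ccc(Cn2c(-c3ccccc3O)c(Br)c3ccccc3c2=O)cc1` and compound 4 `COc1ccc(Cn2c(-c3ccccc3O)c(Br)c3cc(C)ccc3c2=O)cc1` another, and the difference between the two cores is not broken down here. In a functional assay on A549 cells (Homo sapiens) for cytotoxicity, read by sulforhodamine B assay (a lower number here means a stronger inhibitor, a higher number a weaker inhibitor), compound 1 gives only a limit, > 100000 nM, a point marked by the limit of > 100000 nM in this assay, at which 1 of the 3 values shown sits. Compound 2 gives 99800 nM in this assay. The change from compound 1 to compound 2 is methyl in place of hydrogen on an aromatic carbon, and the step of a number no higher from compound 1 to compound 2 (the limit leaves the size open). Compound 3 gives 71300 nM in this assay. Compound 4 differs from compound 3 by the same change, (methyl in place of hydrogen on an aromatic carbon). Resting on the measured step of a number no higher from compound 1 to compound 2 (the limit leaves the size open), which leaves its size open, the step to compound 4 is expected to be small, a 1.2-fold lower number from compound 3 to compound 4 (0.07 log units; within the scatter). In this assay compound 4 is therefore estimated at 60000 nM, expected to fall between 25000 nM and 150000 nM.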

Compound 4, half-maximal inhibitory concentration: 53000 nM
Compound 4: middle estimate off by 1.1-fold (0.05 log units), on the high side; the range from low to high includes it.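

In this assay, methyl in place of hydrogen on an aromatic carbon gives a 1.3-fold lower number from compound 3 to compound 4 (0.13 log units; within the scatter), so on this second core the change has no effect that can be told from the scatter. Compound 1 is recorded only as a limit, which leaves the size of the first step unread: the limit of > 100000 nM in this assay, at which 1 of the 4 values shown sits. This shows that the second step is small, but not that the change carries over from one core to the other with the same size: the same change on two cores in this assay, a number no higher (the limit leaves the size open) from compound 1 to compound 2 and a 1.3-fold lower number (0.13 log units; within the scatter) from compound 3 to compound 4; the limit leaves it open whether they differ

The compounds shown leave open whether another group on that aromatic carbon, such as an amine, a carboxylic acid or a longer chain, would move the number beyond the scatter on either core.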